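The source may report more compounds than this note shows. Statements on the series, on what has been measured and on what is new or still open speak of the compounds shown alone.

Compounds measured in a functional assay on MCF7 cells (Homo sapiens) for inhibition, read by sulforhodamine B assay, with a stated time of 48 h, tested at 50 uM; a higher number here means more inhibition of growth at the concentration tested, a lower number less inhibition of growth:
compound 1 `COc1ccc([C@@H]2C/C(=N/OCc3cn(-c4cccc(CO)c4)nn3)c3cc(CC=C(C)C)c(OC)cc3O2)cc1` — 42%
compound 2 `COc1cc2c(cc1CC=C(C)C)/C(=N/O)C[C@@H](c1ccc(O)cc1)O2` — 93%
compound 3 `CCCCOc1ccc([C@@H]2CC(=O)c3cc(CC=C(C)C)c(OC)cc3O2)cc1` — 57%

Among these three, compound 1 stands lowest in this assay. Its nearest neighbour is compound 3, whose number lies beyond the scatter above it, and compound 2 lies furthest, well beyond the scatter above compound 1.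

Compound 4 `COc1ccc([C@@H]2C/C(=N/OCc3cn(-c4ccc(NC(C)=O)cc4)nn3)c3cc(CC=C(C)C)c(OC)cc3O2)cc1` is the unmeasured analogue. It differs from compound 1 in one place: 4-acetamidophenyl in place of 3-(hydroxymethyl)phenyl on an aromatic nitrogen. Among the measured compounds shown here, no pair of measured compounds shows the effect of such a change on the aromatic nitrogen, so no size of step can be read from the data. The step of a number 3 percentage points higher from compound 1 to compound 4 (within the scatter) is expected to stay within the scatter, with no clear direction. For compound 4 the estimate in this assay is 45%, in the range 25% to 65%.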

Compound 4, percent growth inhibition at one concentration: 0%
The estimate for compound 4 lay 45 percentage points above the measured number; measured number outside the range, below it.
By their numbers in this assay, from the lowest: compound 4; then compound 1; then compound 3; then compound 2.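

In this assay, the group on the aromatic nitrogen proves to matter: 4-acetamidophenyl in place of 3-(hydroxymethyl)phenyl gives a number 42 percentage points lower from compound 1 to compound 4 (beyond the scatter). The earlier compounds shown here could not show this, and the step now shows that this position does not tolerate every phenyl group equally. Nothing available explains the size of this step. As far as these compounds go, what a 4-(hydroxymethyl)phenyl or a 4-aminophenyl group would give on the same nitrogen stays open. So does the question of whether the acetamide itself or its place on the phenyl ring carries the step.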